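The compounds below may be only part of what the source reports. "The series", "measured", "known", "first", "only" and "open" are said of these compounds alone.

Compound 1 `CC(C(=O)N1CCN(c2ccccc2F)CC1)N1C(=O)CCC1=O` is the reference point of this small set. In a functional assay on the whole organism (strain Swiss) with Mus musculus as the target, in the maximal electroshock model, with a stated time of 0.25 h, at a dose of 300 mg/kg by the intraperitoneal route (a lower number here means a weaker effect, a higher number a stronger effect of the compound at the dose given), compound 1 gives 100%. Two measured neighbours differ from it in one place each. Compound 2 `CCC(C(=O)N1CCN(c2ccccc2F)CC1)N1C(=O)CCC1=O` gives 100% in this assay, and compound 3 `CC(C(=O)N1CCN(c2ccccc2C(F)(F)F)CC1)N1C(=O)CCC1=O` gives 100%. The step of no change at the digits printed from compound 1 to compound 2 (within the scatter) and the step of no change at the digits printed from compound 1 to compound 3 (within the scatter) both leave the read-out where compound 1 already stands, so compound 1 is level with compound 2 and with compound 3 at the digits shown, and no compound of the three can be called stronger or weaker than another.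

The unmeasured compound 4 `Cc1cccc(N2CCN(C(=O)C(C)N3C(=O)CCC3=O)CC2)c1` is reached from compound 1 by the change (3-methylphenyl in place of 2-fluorophenyl on an amine nitrogen in a ring). Of the measured steps, only no change at the digits printed from compound 1 to compound 3 (within the scatter) touches the aromatic ring on the amine nitrogen, and it produced no change beyond the scatter; the step of no change at the digits printed from compound 1 to compound 2 (within the scatter) concerns the saturated chain and bears on compound 4 only in showing that the shared core tolerates small alterations without loss at this dose. Among the compounds with values here, no measured step exchanges fluoro for methyl, so the expectation for compound 4 rests on these two unchanged steps alone. Compound 4 is therefore expected to show a step of no change at the digits printed from compound 1 to compound 4 (within the scatter), that is none beyond the scatter. The estimate for compound 4 in this assay is 100%, within a range from 80% to 100%.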

Compound 4, a percentage reported as activity, at one dose (the size of the read-out at that dose, not a potency): 100%
Compound 4: middle estimate and measured number agree at the digits printed, within the range that was stated.
By their numbers in this assay, from the lowest: compounds 1, 2, 3 and 4 (each within the scatter of the next).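

In this assay, replacing 2-fluorophenyl with 3-methylphenyl on the amine nitrogen in a ring gives no change at the digits printed from compound 1 to compound 4 (within the scatter). Compound 3 had shown that this aromatic ring can carry trifluoromethyl in place of fluoro without a change beyond the scatter, whereas this step shows the same for a group that has no fluorine at all and whose name places its substituent at a different number on the ring. Because fluorine and that number change together, the step cannot show which of the two matters or whether either does, and no measurement offered here explains the unchanged read-out.

On these data alone, since all four compounds print the same value at this single dose, it remains open whether they would separate at a lower dose. As far as these compounds go, it is also open whether an amine or a carboxylic acid on this aromatic ring, or a longer chain in place of the methyl group of compound 4, would leave this assay where it stands.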